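Cyano to carbamoyl on the chain of compound 1

The source may report more compounds than this note shows. Statements on the series, on what has been measured and on what is new or still open speak of the compounds shown alone.

Compound 1 `N#CCCn1nc(-c2ccccc2)ccc1=O` stands lowest of the two compounds measured in a functional assay on the whole organism (stomach) for inhibition, with Rattus norvegicus as the target, at a dose of 100 mg/kg by the intraduodenal route (on this read-out higher numbers stand for more inhibition at the one dose given (going by the name of the read-out) and lower numbers for less inhibition), where compound 1 gives 10.1%. Compound 2 `N=C(S)CCn1nc(-c2cccs2)ccc1=O` gives 50.2% in this assay, a gap beyond the scatter, but compound 2 differs from compound 1 in more than one place, so only the two values themselves are known. Compound 3 `NC(=O)CCn1nc(-c2ccccc2)ccc1=O` has not yet been measured. The change from compound 1 to compound 3 is carbamoyl in place of cyano on a saturated chain carbon, two bonds along the chain from an aromatic nitrogen. For the measured compounds named here, with no single-change step on record, a step of modest size upward is expected, a number 14.9 percentage points higher from compound 1 to compound 3 (beyond the scatter). Compound 3 is therefore estimated at 25%, with a range from 5% to 55%.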

Compound 3, a percentage reported as inhibition, in the whole organism at one dose (the size of the read-out at that dose, not a potency): -2.8%
Estimate against measurement, compound 3: 27.8 percentage points above; the measured number lies below the stated range.
By their numbers in this assay, from the lowest: compound 3; then compound 1; then compound 2.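

In this assay, the step for carbamoyl in place of cyano on a saturated chain carbon, two bonds along the chain from an aromatic nitrogen, runs downward: a number 12.9 percentage points lower from compound 1 to compound 3 (beyond the scatter). This single change, which brings in one hydrogen-bond donor, therefore goes with less inhibition at this position on the core of compound 1. No measurement shown explains this step.

On these data alone, it remains open how a carboxylic acid or an amine at this position, or a longer chain, would compare. How much of the higher value of compound 2 comes from its chain group also cannot be read.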